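This account rests on a few compounds, and the source may have more. Where it says the series, first, only, none or still open, it means among the compounds named here.

Compound 1, `NC[C@@H]1CCN(c2cc3c(cc2F)c(=O)c(C(=O)O)cn3Cc2nc(-c3ccncc3)no2)C1`, is reported in an assay on isolated protein for inhibition of DNA topoisomerase 1 (Homo sapiens), with a stated time of 15 min (on this read-out lower numbers stand for stronger inhibition and higher numbers for weaker inhibition), only as a limit, > 200000 nM.
Compound 2, `NC[C@@H]1CCN(c2cc3c(cc2F)c(=O)c(C(=O)O)cn3Cc2cc(-c3ccccc3)no2)C1`, gives in this assay a value of 58300 nM.
Compound 3, `NC[C@@H]1CCN(c2cc3c(cc2F)c(=O)c(C(=O)O)cn3Cc2ccc(-n3cccn3)cc2)C1`, gives in this assay a value of 91600 nM.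

All three compounds share one core and differ only in the aromatic group attached to the saturated chain carbon bound to an aromatic nitrogen. Exchanging that group gives an at least 3.4-fold lower number from compound 1 to compound 2 (0.53 log units; beyond the scatter) and an at least 2.1-fold lower number from compound 1 to compound 3 (0.33 log units; beyond the scatter), while between the two replacements there is a 1.6-fold higher number from compound 2 to compound 3 (0.20 log units; within the scatter). Compound 1 thus stands at the weak end of the data, sitting at the limit of > 200000 nM in this assay, at which 1 of the 3 values shown sits, so its inhibition is known only as a limit.

Compound 4, `CC(c1nc(-c2ccncc2)no1)n1cc(C(=O)O)c(=O)c2cc(F)c(N3CC[C@@H](CN)C3)cc21`, is not yet measured. It differs from compound 1 by methyl in place of hydrogen on a saturated chain carbon bound to an aromatic carbon and an aromatic nitrogen; the pyridinyl-oxadiazolyl group itself is kept. Within the data shown here, none of the measured steps touches this position; each of them swaps the aromatic group instead, so they give no direct guidance. With no evidence for a change, the expectation is a step of a number no higher from compound 1 to compound 4 (the limit leaves the size open), that is nothing beyond the scatter. Compound 4 is therefore estimated at 200000 nM, in a range from 100000 nM to 400000 nM, and most likely again reported only as a limit.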

Compound 4, half-maximal inhibitory concentration: > 200000 nM
Compound 4: a limit, no number (the forecaster's own chance of this, stated with the estimate: 70%); the middle value lies on the limit itself.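

Compound 1 and compound 4 are both reported only as limits, not as numbers, so the step from one to the other cannot be read: the limit of > 200000 nM in this assay, at which 2 of the 4 values shown sit.

The compounds shown leave open whether methyl in place of hydrogen at this saturated chain carbon changes inhibition at all.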